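A few compounds are considered here, and "the series" means these few. Any claim that something is new, unique, unknown or untested is made for them only; others in the source may bear on it.

Among the compounds with values here, compound 2 `Cc1cccc(Cn2cc(COc3ccc4c(=O)ccoc4c3)nn2)c1` stands lowest of the two numbers so far recorded in a functional assay on SW480 cells (Homo sapiens) for cytotoxicity, read by MTT assay, with a stated time of 48 h; a higher number here means a weaker inhibitor, a lower number a stronger inhibitor: compound 2 gives 11700 nM, while compound 1 `O=c1ccoc2cc(OCc3cn(Cc4ccccc4)nn3)ccc12` gives 42900 nM. Within the data shown here, the single measured step, a 3.7-fold lower number from compound 1 to compound 2 (0.56 log units; beyond the scatter), is the only change for which a number exists. Compound 3 `O=c1ccoc2cc(OCc3cn(Cc4cccc(Br)c4)nn3)ccc12` has not yet been measured; it differs from compound 2 by bromo in place of methyl on an aromatic carbon. Among the measured compounds shown here, no measured step exchanges one group for another on that aromatic carbon, so nothing here bears directly on the change. The only step available, from compound 1 to compound 2, shows that filling that carbon with methyl in place of hydrogen lowered the number by a modest amount beyond the scatter, but whether bromo in place of methyl moves the number again is not shown by any pair here. Compound 3 is therefore expected to sit close to compound 2, with a step of a 1.2-fold lower number from compound 2 to compound 3 (0.07 log units; within the scatter) that is not expected to reach beyond the scatter. For compound 3 the estimate in this assay is 10000 nM, within a range from 4000 nM to 30000 nM.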

Compound 3, half-maximal inhibitory concentration: > 100000 nM
Compound 3: only a limit was reported; the forecaster's own chance of this, stated with the estimate: 5%; middle value at least 10-fold (1.00 log units) away from the limit.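

In this assay compound 3 gives > 100000 nM, which is a limit of the assay and not a number. Within the data shown here, this carbon, meta to a large group, proves sensitive to more than the earlier pair could show: bromo in place of methyl gives an at least 8.5-fold higher number from compound 2 to compound 3 (0.93 log units; beyond the scatter), opposite in direction to the only earlier change, a 3.7-fold lower number from compound 1 to compound 2 (0.56 log units; beyond the scatter). Bromo in place of hydrogen also raises the number, with an at least 2.3-fold higher number from compound 1 to compound 3 (0.36 log units; beyond the scatter), so methyl and bromo move it in opposite directions from the unsubstituted benzyl compound, although both bromo steps are bounds and not exact sizes: the limit of > 100000 nM in this assay, at which 1 of the 3 values shown sits.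

The compounds shown leave open how chloro, methoxy or an amine on this same carbon would fall relative to methyl and bromo, and so whether the rise in the number belongs to bromo alone. They also leave open how far past its limit compound 3 lies and how bromo would read on another carbon of that ring.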